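Does a still longer chain weaken inhibition further?

A few compounds are considered here, and "the series" means these few. Any claim that something is new, unique, unknown or untested is made for them only; others in the source may bear on it.

In a functional assay (brain) for inhibition, with Rattus norvegicus as the target (on this read-out higher numbers stand for weaker inhibition and lower numbers for stronger inhibition), compound 1 `CCCCCCCCCOC1=C(O)OC(C(O)CO)C1=O` gives 0.027 nM and compound 2 `CCCCCCCCCCCCCCOC1=C(O)OC(C(O)CO)C1=O` gives 7400 nM as the higher of the two numbers, so compound 2 is the weaker inhibitor. Compound 3 `CCCCCCCCCCCCCCCCCCCCCOC1=C(O)OC(C(O)CO)C1=O` lengthens the chain again, with heptyl in place of hydrogen on a saturated chain carbon, ten or more bonds along the chain from an oxygen on an unsaturated carbon as the change. Going by the values given here, the only measured step that bears on this, also a chain lengthening, is a 270000-fold higher number from compound 1 to compound 2 (5.44 log units; beyond the scatter) and lies far beyond the scatter. Resting on that single step, a 2.7-fold higher number from compound 2 to compound 3 (0.43 log units; beyond the scatter) is the expected change, in the same direction but much smaller and quite uncertain. For compound 3 the expected value is 20000 nM within an estimated range from 1500 nM to 300000 nM for now.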

Compound 3, half-maximal inhibitory concentration: 11000 nM
Compound 3: the middle estimate sits 1.8-fold (0.26 log units) above what was measured; measured number inside the range.
By their numbers in this assay, from the lowest: compound 1; then compounds 2 and 3 (each within the scatter of the next).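

Putting heptyl on a saturated chain carbon gives a 1.5-fold higher number from compound 2 to compound 3 (0.17 log units; within the scatter) in this assay, so compounds 2 and 3 cannot be told apart. The large step seen with pentyl, a 270000-fold higher number from compound 1 to compound 2 (5.44 log units; beyond the scatter), does not recur with this longer addition. No supporting measurement shows what lies behind this difference between the two steps.

Open, from the compounds shown here alone, is how a chain shorter than that of compound 1 would read. Also open, going by these compounds, is whether an amine or a carboxylic acid at the end of the chain would change the number.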